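Cyclopropyl to 4-(Trifluoromethyl)phenyl on the Sulfonyl Sulfur

This account rests on a few compounds, and the source may have more. Where it says the series, first, only, none or still open, it means among the compounds named here.

Of the compounds shown here, three sharing one core have been measured in a functional assay on MDA-MB-231 cells (Homo sapiens) for inhibition, read by sulforhodamine B assay, tested at 10 uM; on this read-out higher numbers stand for more inhibition at the one concentration tested (going by the name of the read-out) and lower numbers for less inhibition. Compound 1 `CN1CCN(c2ccc(C3=NN(C(=O)CCCl)C(c4ccc(N(C)C)cc4)C3)cc2)CC1` gives 2.4%, compound 2 `CN1CCN(c2ccc(C3=NN(C(=O)/C=C/c4ccccc4)C(c4ccc(N(C)C)cc4)C3)cc2)CC1` gives 35.9%, and compound 3 `CN1CCN(c2ccc(C3=NN(S(=O)(=O)C4CC4)C(c4ccc(N(C)C)cc4)C3)cc2)CC1` gives 3.7%. Compound 3 stands second highest of the three: compound 1 is within the scatter of it, while compound 2 sits well above it, as the step of a number 32.2 percentage points lower from compound 2 to compound 3 (beyond the scatter) shows. The step of a number 1.3 percentage points higher from compound 1 to compound 3 (within the scatter) was flat, whereas a number 33.5 percentage points higher from compound 1 to compound 2 (beyond the scatter) was large.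

Compound 4 `CN1CCN(c2ccc(C3=NN(S(=O)(=O)c4ccc(C(F)(F)F)cc4)C(c4ccc(N(C)C)cc4)C3)cc2)CC1` differs from compound 3 in one place: 4-(trifluoromethyl)phenyl in place of cyclopropyl on a sulfonyl sulfur. Going by the values given here, no measured step changes the group on a sulfonyl sulfur, so nothing directly comparable exists. Among the compounds with values here, the only large step seen, a number 33.5 percentage points higher from compound 1 to compound 2 (beyond the scatter), involved a group containing a phenyl ring entering on a carbonyl carbon, a different place. A rise of some size in this assay is therefore possible but uncertain, and the expected step of a number 11.3 percentage points higher from compound 3 to compound 4 (beyond the scatter) is taken as modest. Compound 4 is estimated at 15%, within 0% to 40%.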

Compound 4, a percentage reported as inhibition, at one concentration (the size of the read-out at that concentration, not a potency): 12.1%
The estimate for compound 4 lay 2.9 percentage points above the measured number, and the stated range covers the measured number.
By their numbers in this assay, from the lowest: compounds 1, 3 and 4 (each within the scatter of the next); then compound 2.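

Exchanging cyclopropyl for 4-(trifluoromethyl)phenyl on the sulfonyl sulfur gives a number 8.4 percentage points higher from compound 3 to compound 4 (within the scatter) in this assay, so this first change at the position cannot be told apart from repeat-measurement noise. An aromatic ring entering here therefore does not repeat the large step of a number 33.5 percentage points higher from compound 1 to compound 2 (beyond the scatter) that came with 2-phenylethenyl on a carbonyl carbon, and a group of 10 heavy atoms in place of one of 3 leaves the number within the scatter. The data shown offer no measurement that could explain this flat result.

As far as these compounds go, it remains open whether a 2-phenylethenyl group on the sulfonyl sulfur would give a step beyond the scatter. An amine or a carboxylic acid on the phenyl ring at this position is also untested in the compounds shown.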